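A few compounds are considered here, and "the series" means these few. Any claim that something is new, unique, unknown or untested is made for them only; others in the source may bear on it.

Compound 1, `O=C(O)c1csc([C@H]2CC[C@@H]3[C@@H](COc4ccc(F)cc4)[C@H](O)C[C@@H]3O2)n1`: > 10000 nM
Compound 2, `O=C(O)c1csc([C@H]2CC[C@@H]3[C@@H](/C=C/COc4ccccc4)[C@H](O)C[C@@H]3O2)n1`: > 10000 nM
Compound 3, `O=C(O)c1csc([C@H]2CC[C@@H]3[C@@H](/C=C/CCOc4ccccc4)[C@H](O)C[C@@H]3O2)n1`: > 10000 nM

Each of these three values is a limit of an assay on HEK293 cells for agonist activity at prostaglandin E2 receptor EP2 subtype (Homo sapiens), read by a beta-galactosidase reporter and beta-arrestin recruitment, with a stated time of 90 min (on this read-out higher numbers stand for an effect only at larger amounts of compound and lower numbers for an effect already at smaller amounts), not a measured number. Compound 1 therefore stands at the limit, where the limit of > 10000 nM in this assay, at which 3 of the 3 values shown sit, places every value obtained so far. Within the data shown here, the one comparison between measured compounds, a step that the two limits leave unreadable from compound 2 to compound 3, is unreadable for the same reason. Compound 4, `O=C(O)c1csc([C@H]2CC[C@@H]3[C@@H](COc4ccccc4Cl)[C@H](O)C[C@@H]3O2)n1`, differs from compound 1 as follows: 2-chlorophenyl in place of 4-fluorophenyl on an oxygen on a saturated carbon. Among the measured compounds shown here, no measured step bears on this change, and the single step available concerns a different alteration and gives no size. With every known value at the limit, compound 4 is expected to remain at or near it, a step that the limit leaves unreadable from compound 1 to compound 4. Compound 4 is accordingly estimated at 15000 nM, between 4000 nM and 60000 nM.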

Compound 4, half-maximal effective concentration: 203 nM
The estimate for compound 4 lay 74-fold (1.87 log units) above the measured number, and the stated range ends above it.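

Compound 4 is the only compound shown with a measured number in this assay, so the group on this oxygen can separate a measured value from the limit: the limit of > 10000 nM in this assay, at which 3 of the 4 values shown sit. Putting 2-chlorophenyl in place of 4-fluorophenyl gives an at least 49-fold lower number from compound 1 to compound 4 (1.69 log units; beyond the scatter), although the group keeps the same count of heavy atoms.

Both the halogen and its place on the ring change in this step, and the compounds shown leave open which of them carries it. From the compounds shown here alone, how 2-fluorophenyl or 4-chlorophenyl would read on this oxygen also remains open.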